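This account rests on a few compounds, and the source may have more. Where it says the series, first, only, none or still open, it means among the compounds named here.

Four compounds are set side by side in an ADME assay on HUVEC cells (Homo sapiens) for antiproliferative activity, read by MTT assay, with a stated time of 48 h; on this read-out lower numbers stand for stronger inhibition and higher numbers for weaker inhibition. Compound 1 `CCOc1ccccc1-n1nncc1CN1C(=O)C2(C(C#N)=C(N)Oc3c2c2nc4ccccc4nc2c2ccccc32)c2ccccc21` and compound 2 `N#CC1=C(N)Oc2c(c3nc4ccccc4nc3c3ccccc23)C12C(=O)N(Cc1cnnn1-c1ccc([N+](=O)[O-])cc1)c1ccccc12` share one core, while compound 3 `CCOc1ccccc1-n1nncc1CN1C(=O)C2(C(C#N)=C(N)Oc3c(N)cc4nc5ccccc5nc4c32)c2ccccc21` and compound 4 `N#CC1=C(N)Oc2c(N)cc3nc4ccccc4nc3c2C12C(=O)N(Cc1cnnn1-c1ccc([N+](=O)[O-])cc1)c1ccccc12` share a second; the difference between the two cores is not broken down here. In this assay compound 1 gives > 50000 nM, which is a limit of the assay rather than a number. Compound 2 likewise gives > 50000 nM, again a limit. Compound 3 gives > 50000 nM, also a limit. The change from compound 1 to compound 2 is 4-nitrophenyl in place of 2-ethoxyphenyl on an aromatic nitrogen, and it made a step that the two limits leave unreadable from compound 1 to compound 2; the size of that step cannot be read because of the limit of > 50000 nM in this assay, at which 3 of the 3 values shown sit. The same change is now made from compound 3 to compound 4, namely (4-nitrophenyl in place of 2-ethoxyphenyl on an aromatic nitrogen), at a place described in identical words. Compound 4 has not yet been measured in this assay. Because (the limit of > 50000 nM in this assay, at which 3 of the 3 values shown sit), compound 4 is expected to give 60000 nM, most likely reported again only as a limit, within an estimated range from 20000 nM to 200000 nM. The expected step is a step that the limit leaves unreadable from compound 3 to compound 4, which rests on no measured size.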

Compound 4, half-maximal inhibitory concentration: > 50000 nM
Compound 4 ended at the assay's limit (the forecaster's own chance of this, stated with the estimate: 85%); the middle value is on the limit's open side.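

In this assay compound 3 and compound 4 yield no readable step, because both stand at a limit of the assay rather than at a number: the limit of > 50000 nM in this assay, at which 4 of the 4 values shown sit. The compounds shown leave open how far each lies past that limit, and whether 4-nitrophenyl in place of 2-ethoxyphenyl changes activity on either core.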